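The compounds below may be only part of what the source reports. "The series", "measured", "known", "first", "only" and "open" are said of these compounds alone.

In a functional assay on MCF7 cells (Homo sapiens) for inhibition, read by MTT assay, with a stated time of 48 h (on this read-out higher numbers stand for weaker inhibition and lower numbers for stronger inhibition), compound 3 `COc1ccc(/C=C2\SC(=O)N(CC(=O)Nc3c(C)n(C)n(-c4ccccc4)c3=O)C2=O)cc1` gives 75600 nM as its reading, the highest of the three numbers in hand. In this assay compound 1 `Cc1ccc(/C=C2\SC(=O)N(CCNC(=O)Nc3c(C)n(C)n(-c4ccccc4)c3=O)C2=O)cc1` gives 37400 nM and compound 2 `Cc1c(NC(=O)NCCN2C(=O)S/C(=C\c3ccc([N+](=O)[O-])cc3)C2=O)c(=O)n(-c2ccccc2)n1C` gives 18600 nM as their readings. Compound 3 stands beyond the scatter from both of them, but it differs from them in more than one place, so no single-change comparison links it to either.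

The change under study leads to compound 4 `Cc1cc(C)c(/C=C2\SC(=O)N(CC(=O)Nc3c(C)n(C)n(-c4ccccc4)c3=O)C2=O)c(C)c1` and reads 2,4,6-trimethylphenyl in place of 4-methoxyphenyl on a double-bonded chain carbon bound to a double-bonded ring carbon. Within the data shown here, the only measured step touching that aromatic ring is a 2.0-fold lower number from compound 1 to compound 2 (0.30 log units; within the scatter) (nitro in place of methyl on an aromatic carbon). That step lies within the scatter and comes from compounds with a different chain, so no step beyond the scatter is expected for compound 4 in this assay. Among the measured compounds shown here, it is a thin guide, since no measured compound carries 2,4,6-trimethylphenyl. The expected change is a 1.3-fold lower number from compound 3 to compound 4 (0.10 log units; within the scatter) and is estimated to stay within the scatter. Compound 4 is estimated at 60000 nM with an expected range of 25000 nM to 140000 nM in these notes.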

Compound 4, half-maximal inhibitory concentration: 71100 nM
For compound 4 the middle estimate is 1.2-fold (0.07 log units) below the measured one, within the range that was stated.
By their numbers in this assay, from the lowest: compounds 2, 1, 4 and 3 (each within the scatter of the next, the first and the last beyond it).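

In this assay, among these compounds, the replacement of 4-methoxyphenyl by 2,4,6-trimethylphenyl on a double-bonded chain carbon bound to a double-bonded ring carbon gives a 1.1-fold lower number from compound 3 to compound 4 (0.03 log units; within the scatter), the first step at this position on the chain shared by these two compounds, whereas the only earlier step came from compounds with a different chain. At this position and on this chain, the read-out therefore does not separate the two aryl groups, even though the methoxy oxygen is lost and the three methyl groups enter. The data on hand offer no measurement that accounts for this outcome.

The compounds shown leave open what a dimethylamino group or a carboxylic acid on this aromatic ring would do on this chain, and whether the nitro in place of methyl seen on the other chain would give a comparable step here. Among the compounds shown here, the contribution of the chain itself also remains unresolved, as no pair among compounds 1, 2, 3 and 4 differs in the chain alone.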